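From 4-nitrophenyl to 3-cyanophenyl: one more amide variant

The source may hold more compounds than are shown below. What is called first, only, known or untested is meant among the compounds shown, and "the series" means these compounds.

Measured in a functional assay on HepG2 cells (Homo sapiens) for inhibition, read by MTT assay (on this read-out lower numbers stand for stronger inhibition of growth and higher numbers for weaker inhibition of growth), so far:
compound 1 `COc1cc2oc(-c3cccc(NC(=O)c4cccc(Br)c4)c3)cc(=O)c2c(OC)c1OC` gives 10900 nM
compound 2 `COc1cc2oc(-c3cccc(NC(=O)c4ccc(Cl)cc4)c3)cc(=O)c2c(OC)c1OC` gives 21300 nM
compound 3 `COc1cc2oc(-c3cccc(NC(=O)c4ccc([N+](=O)[O-])cc4)c3)cc(=O)c2c(OC)c1OC` gives 18800 nM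

Compound 3 at 18800 nM is not separated from the other two compounds, as the steps show: a 1.1-fold lower number from compound 2 to compound 3 (0.05 log units; within the scatter) and a 1.7-fold higher number from compound 1 to compound 3 (0.24 log units; within the scatter). Compound 4 `COc1cc2oc(-c3cccc(NC(=O)c4cccc(C#N)c4)c3)cc(=O)c2c(OC)c1OC` differs from compound 3 by one change, 3-cyanophenyl in place of 4-nitrophenyl on a carbonyl carbon. The measured steps at that carbonyl carbon, which also include a 2.0-fold higher number from compound 1 to compound 2 (0.29 log units; within the scatter), all stay within the scatter, so no step beyond the scatter is expected in this assay. The expected step is a 1.2-fold lower number from compound 3 to compound 4 (0.07 log units; within the scatter). Compound 4 is therefore estimated at 16000 nM (expected range 8000 nM to 32000 nM).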

Compound 4, concentration for 50% growth inhibition: 11900 nM
Beside the measured number, compound 4's estimate is 1.3-fold (0.13 log units) above it, and the stated range covers the measured number.
By their numbers in this assay, from the lowest: compounds 1, 4, 3 and 2 (each within the scatter of the next).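

In this assay the 3-cyanophenyl amide, compound 4, stays within the scatter of the 4-nitrophenyl amide (a 1.6-fold lower number from compound 3 to compound 4 (0.20 log units; within the scatter)), the 4-chlorophenyl amide (a 1.8-fold lower number from compound 2 to compound 4 (0.25 log units; within the scatter)) and the 3-bromophenyl amide (a 1.1-fold higher number from compound 1 to compound 4 (0.04 log units; within the scatter)). A nitrile on the phenyl at this carbonyl carbon therefore joins the bromo, chloro and nitro groups without separating from any of them. A phenyl carrying an amine or a carboxylic acid lies outside the compounds shown, so whether any change here can move the number beyond the scatter remains open. Nothing available explains why these four amides read alike.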